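This account rests on a few compounds, and the source may have more. Where it says the series, first, only, none or still open, it means among the compounds named here.

In an ADME assay on microsomes (Mus musculus) for metabolic stability, read by LC-MS, using NADPH, with a stated time of 1 h, tested at 1 uM (on this read-out higher numbers stand for fast clearance and lower numbers for slow clearance), compound 1 `Nc1n[nH]c2cc(-c3ccc(=O)n(Cc4cccc(Cl)c4)c3)ccc12` gives < 10 mL.min-1.g-1, a limit of the assay and not a number. Compound 1 thus stands at the limit of < 10 mL.min-1.g-1 in this assay, at which 1 of the 2 values shown sits. Compound 2 `CC(=O)Nc1cccc(Cn2cc(-c3ccc4c(N)n[nH]c4c3)ccc2=O)c1` gives 14 mL.min-1.g-1 in this assay. Among the compounds with values here, the only measured step, acetamido in place of chloro on an aromatic carbon, is an at least 1.4-fold higher number from compound 1 to compound 2 (0.14 log units; that floor lies within the scatter), and it does not touch the amino group. Compound 3 `O=c1ccc(-c2ccc3cn[nH]c3c2)cn1Cc1cccc(Cl)c1` differs from compound 1 by hydrogen in place of amino on an aromatic carbon. Within the data shown here, with no measured step at this place, the expected change in this assay is small and upward, an at least 1.2-fold higher number from compound 1 to compound 3 (0.07 log units; that floor lies within the scatter). For compound 3 the estimated value is 12 mL.min-1.g-1, with an expected range of 6 mL.min-1.g-1 to 30 mL.min-1.g-1.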

Compound 3, intrinsic clearance in microsomes: 52 mL.min-1.g-1
Estimate against measurement, compound 3: 4.3-fold (0.64 log units) below, and the stated range ends below it.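

At this place on the five-membered aromatic ring, hydrogen in place of amino on an aromatic carbon gives in this assay an at least 5.2-fold higher number from compound 1 to compound 3 (0.71 log units; beyond the scatter). Unlike the acetamido change, this step touches the amino group, and it is the only step shown that lies beyond the scatter. Compound 1 gives a limit and not a number, so the step is only a floor: the limit of < 10 mL.min-1.g-1 in this assay, at which 1 of the 3 values shown sits.

The compounds shown leave open whether a methylamino or hydroxyl group at this place would give a number nearer that of compound 1 or compound 3. They also leave open whether hydrogen in place of amino would give a similar step on compound 2.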